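The source may hold more compounds than are shown below. What is called first, only, known or untested is meant among the compounds shown, and "the series" means these compounds.

In an assay on isolated protein for inhibition of cathepsin S (Homo sapiens), read by fluorescence, with a stated time of 20 min (a lower number here means a stronger inhibitor, a higher number a weaker inhibitor), compound 3 `N#CC1(NC(=O)[C@@H]2C[C@@H](S(=O)(=O)c3ccccc3)C[C@H]2C(=O)N2CC3CCC(C2)O3)CC1` gives 1 nM, the lowest number among the three measured compounds. Compound 1 `CC(C)(C#N)NC(=O)[C@@H]1C[C@@H](S(=O)(=O)c2ccccc2)C[C@H]1C(=O)N1CCOCC1` gives 3 nM and compound 2 `N#CC1(NC(=O)[C@@H]2C[C@@H](S(=O)(=O)c3ccccc3)C[C@H]2C(=O)N2CCOCC2)CCC1` gives 4 nM, both beyond the scatter from compound 3. Among the compounds with values here, the single measured step, a 1.3-fold higher number from compound 1 to compound 2 (0.12 log units; within the scatter), lies on the nitrile-bearing amide and does not bear on the change to compound 4 `CC1CCN(C(=O)[C@@H]2C[C@H](S(=O)(=O)c3ccccc3)C[C@H]2C(=O)NC2(C#N)CC2)CC1`, which is a group of 7 heavy atoms (6 carbon, 1 nitrogen; one six-membered non-aromatic ring with 1 hetero atom) in place of a group of 8 heavy atoms (6 carbon, 1 nitrogen, 1 oxygen; one five-membered non-aromatic ring with 1 hetero atom, one six-membered non-aromatic ring with 2 hetero atoms), on a carbonyl carbon. Compound 1 and compound 3 carry different groups on that carbonyl, and their values differ beyond the scatter, so the carbonyl substituent can move the number. For compound 4 a modest loss relative to compound 3 is expected, a 3.0-fold higher number from compound 3 to compound 4 (0.48 log units; beyond the scatter), with an estimated 3 nM in this assay and a range of 1 nM to 10 nM.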

Compound 4, half-maximal inhibitory concentration: 0.5 nM
Compound 4: the middle estimate sits 6.0-fold (0.78 log units) above what was measured; the whole stated range lies above it.
By their numbers in this assay, from the lowest: compounds 4 and 3 (each within the scatter of the next); then compounds 1 and 2 (each within the scatter of the next).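

In this assay, exchange of the group on the carbonyl carbon gives a 2.0-fold lower number from compound 3 to compound 4 (0.30 log units; within the scatter). At this position, a low number therefore does not depend on the oxygen of the departing group or on its second ring, at least in this pair. No available evidence explains this result. From the compounds shown here alone, it remains open whether piperidin-1-yl without the methyl would hold the number in this range. Going by these compounds, it is also open whether a piperazine or a carboxylic acid on the same carbonyl carbon would do so.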